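The source may hold more compounds than are shown below. What is called first, only, known or untested is meant among the compounds shown, and "the series" means these compounds.

Series notes. Compound 1 `O=C(c1cccc(F)c1)N1CCCC[C@@H]1c1nc(-c2cccc(F)c2)no1` in an in vitro functional assay on HEK293-A cells for positive allosteric modulation of metabotropic glutamate receptor 5 (Homo sapiens), read by fluorescence and calcium flux, with a stated time of 140 s (on this read-out lower numbers stand for an effect already at smaller amounts and higher numbers for an effect only at larger amounts of compound), gives 460 nM. Compound 2 `O=C(c1ccc(F)cc1)N1CCCC[C@@H]1c1nc(-c2cccc(F)c2)no1` in this assay gives 23000 nM. The difference between compound 1 and compound 2 is 4-fluorophenyl in place of 3-fluorophenyl on a carbonyl carbon, and the step it made is a 50-fold higher number from compound 1 to compound 2 (1.70 log units; beyond the scatter). Compound 3 `O=C(c1cccc(F)c1)N1CCCC1c1nc(-c2cccc(F)c2)no1` carries a different core; how the cores of compound 1 and compound 3 differ is not broken down here. In this assay compound 3 gives 2600 nM, a higher number than compound 1 and a lower one than compound 2.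

Compound 4 `O=C(c1ccc(F)cc1)N1CCCC1c1nc(-c2cccc(F)c2)no1` has not yet been measured. For the measured compounds named here, it differs from compound 3 by 4-fluorophenyl in place of 3-fluorophenyl on a carbonyl carbon, the same change, at the same place, as the one from compound 1 to compound 2. Because that change gave a 50-fold higher number from compound 1 to compound 2 (1.70 log units; beyond the scatter), a step of comparable size is expected from compound 3 to compound 4 in this assay, namely a 38-fold higher number from compound 3 to compound 4 (1.59 log units; beyond the scatter); this rests on a single earlier instance, so its size is uncertain. For compound 4 the estimate in this assay is 100000 nM, between 25000 nM and 300000 nM, with a real chance that only a limit is reported.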

Compound 4, half-maximal effective concentration: 3600 nM
Beside the measured number, compound 4's estimate is 28-fold (1.44 log units) above it; the measured number lies below the stated range.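

In this assay, 4-fluorophenyl in place of 3-fluorophenyl on a carbonyl carbon gives a 1.4-fold higher number from compound 3 to compound 4 (0.14 log units; within the scatter), so this change produces no readable difference on this core. For the compounds shown here, the size of the step therefore did not carry over from the core of compound 1 to the core of compound 3, and the two instances differ: the same change on two cores in this assay, a 50-fold higher number (1.70 log units; beyond the scatter) from compound 1 to compound 2 and a 1.4-fold higher number (0.14 log units; within the scatter) from compound 3 to compound 4, 36-fold (1.56 log units) apart, beyond the scatter of two such steps With only one pair on each core, this shows that the outcome of the change depends on the core within these four compounds, but it does not show what in the cores sets the difference or how the change would behave on any further core.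

As far as these compounds go, it remains open whether a group such as 3-chlorophenyl, 4-chlorophenyl or 4-methoxyphenyl on the same carbonyl carbon would separate the two cores in the same way. Also open, from the compounds shown here alone, is whether an aliphatic amide substituent such as cyclohexyl would follow either core's behaviour.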